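The compounds below may be only part of what the source reports. "The series", "measured", "known", "first", "only" and "open" are said of these compounds alone.

Measured so far, as half-maximal inhibitory concentration:
- compound 1 `Nc1nc(N)c2c(-c3ccsc3)cn([C@@H]3O[C@H](CO)[C@@H](O)[C@H]3O)c2n1`: > 100000 nM
- compound 2 `Nc1nc(N)c2c(-c3cc4ccccc4o3)cn([C@@H]3O[C@H](CO)[C@@H](O)[C@H]3O)c2n1`: > 20000 nM
- compound 3 `C#Cc1cn([C@@H]2O[C@H](CO)[C@@H](O)[C@H]2O)c2ncnc(OC)c12`: 8160 nM

In a functional assay on A549 cells (Homo sapiens), read by MTT assay, with a stated time of 72 h (on this read-out higher numbers stand for weaker inhibition and lower numbers for stronger inhibition), compound 1 gives > 100000 nM, a limit of the assay. Compound 2 also reaches only a limit, > 20000 nM. For the measured compounds named here, compound 3 gives 8160 nM, the only number among the three. The step that the two limits leave unreadable from compound 1 to compound 2 cannot be read, since both ends are limits.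

Compound 4 `COc1ncnc2c1c(-c1ccccc1)cn2[C@@H]1O[C@H](CO)[C@@H](O)[C@H]1O` differs from compound 3 by phenyl in place of ethynyl on an aromatic carbon. Going by the values given here, no measured step touches this change: the pair compound 1 to compound 2 sits on the core of compound 1, not that of compound 3, and is unreadable anyway. With nothing to anchor a direction, the expected step of a 1.0-fold lower number from compound 3 to compound 4 (0.01 log units; within the scatter) is none beyond the scatter. Compound 4 is therefore estimated at 8000 nM, within 2000 nM to 35000 nM.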

Compound 4, half-maximal inhibitory concentration: > 20000 nM
Compound 4: only a limit was reported; the forecaster's own chance of this, stated with the estimate: 20%; at least 2.5-fold (0.39 log units) between middle value and limit.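

In this assay, for the compounds shown here, phenyl in place of ethynyl, on an aromatic carbon two ring bonds from the ring nitrogen, gives an at least 2.4-fold higher number from compound 3 to compound 4 (0.38 log units; beyond the scatter) on the core of compound 3, the first readable step. Compound 4 gives > 20000 nM as a limit of the assay. As far as these compounds go, the true size of the step therefore stays open on the upper side: the limit of > 20000 nM in this assay, at which 2 of the 4 values shown sit.

This single pair does not separate the aromatic ring from the larger count of heavy atoms. From the compounds shown here alone, how an amine, a carboxylic acid or a longer alkyne chain would read on this carbon stays open.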